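A few compounds are considered here, and "the series" means these few. Any claim that something is new, unique, unknown or untested is made for them only; others in the source may bear on it.

Measured in a functional assay on A-375 cells (Homo sapiens) for cytotoxicity, read by MTT assay; on this read-out higher numbers stand for weaker inhibition and lower numbers for stronger inhibition:
- compound 1 `COc1ccc(/C=C/C(=O)c2ccc(OC)c3c2OC(C)(C)C=C3)cc1OCC=C(C)C`: > 10000 nM
- compound 2 `COc1ccc(/C=C/C(=O)c2ccc(OC)c3c2OC(C)(C)C=C3)cc1OC(=O)CCl`: 450 nM
- compound 3 `COc1ccc(/C=C/C(=O)c2ccc(OC)c3c2OC(C)(C)C=C3)cc1OC(=O)C1CC1`: 380 nM

The entry for compound 1, > 10000 nM, is a limit of the assay and not a number.

Compound 3 stands level with compound 2, as a 1.2-fold lower number from compound 2 to compound 3 (0.07 log units; within the scatter) shows, so neither can be ranked above the other. Both differ sharply from compound 1. The first large change is an at least 22-fold lower number from compound 1 to compound 2 (1.34 log units; beyond the scatter), and the second is an at least 26-fold lower number from compound 1 to compound 3 (1.42 log units; beyond the scatter). In each, a carbonyl-bearing group replaces 3-methylbut-2-en-1-yl on an oxygen on an aromatic ring.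

The next compound is compound 4 `COc1cccc(C(=O)Oc2cc(/C=C/C(=O)c3ccc(OC)c4c3OC(C)(C)C=C4)ccc2OC)c1`, which carries 3-methoxyphenyl in place of cyclopropyl on a carbonyl carbon. The carbonyl stays, so the large steps from compound 1 suggest that most of the gain should be kept. Among the compounds with values here, the best guide is the one measured swap at this same carbonyl carbon, a 1.2-fold lower number from compound 2 to compound 3 (0.07 log units; within the scatter). However, that swap involved only small groups, and the entering 3-methoxyphenyl is larger, so it is an imperfect guide.

A modest move towards a higher number in this assay, meaning weaker inhibition, is therefore expected: a 1.8-fold higher number from compound 3 to compound 4 (0.27 log units; within the scatter). For compound 4 the estimated value is 700 nM, with an expected range of 250 nM to 3000 nM.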

Compound 4, half-maximal inhibitory concentration: 800 nM
Estimate against measurement, compound 4: 1.1-fold (0.06 log units) below; measured number inside the range.
By their numbers in this assay, from the lowest: compounds 3, 2 and 4 (each within the scatter of the next, the first and the last beyond it). At a limit, above all of these: compound 1.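

In this assay, within the data shown here, 3-methoxyphenyl on this carbonyl carbon gives the first step among the compounds with a carbonyl-bearing group on this oxygen that is not lost in the scatter: a 2.1-fold higher number from compound 3 to compound 4 (0.32 log units; beyond the scatter), a modest change, while a 1.8-fold higher number from compound 2 to compound 4 (0.25 log units; within the scatter), so compound 4 cannot be separated from compound 2. The much larger entering group, with an aromatic ring in place of the small cyclopropyl, still leaves a wide gap to the compound with 3-methylbut-2-en-1-yl on this oxygen, with an at least 12-fold lower number from compound 1 to compound 4 (1.09 log units; beyond the scatter), so across these three compounds the gain survives a large change in the group on the carbonyl carbon. The entry for compound 1 is a limit of the assay and not a number, so that step has no exact size: the limit of > 10000 nM in this assay, at which 1 of the 4 values shown sits.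

A plain phenyl on this carbonyl carbon would show how much of the modest step belongs to the ring and how much to its methoxy group. Going by these compounds, it also remains open how a longer chain or a group carrying an amine at this carbonyl carbon would read in this assay.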